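The source may hold more compounds than are shown below. What is called first, only, known or untested is meant among the compounds shown, and "the series" means these compounds.

Compound 1 `Cc1ccc2c(c1)/C(=N/N1CC(=O)N(CCCCN3CCN(C)CC3)C1=O)CCO2` reaches only > 100000 nM in an assay on cells (Ventricular myocyte) for inhibition of potassium voltage-gated channel subfamily KQT member 1 (Cavia porcellus), read by patch clamp (a lower number here means a stronger inhibitor, a higher number a weaker inhibitor), which is a limit of the assay rather than a number. Compound 2 `O=C1CN(/N=C2\CCOc3ccc(O)cc32)C(=O)N1CCCCN1CCCCC1` gives 5400 nM in this assay, the only number shown there. The remaining value, that of compound 1, is a limit (the limit of > 100000 nM in this assay, at which 1 of the 2 values shown sits). Compound 3 `Cc1ccc2c(c1)/C(=N/N1CC(=O)N(CCCCN3CCCCC3)C1=O)CCO2` is not yet measured; it differs from compound 2 by methyl in place of hydroxy on an aromatic carbon. For the measured compounds named here, no measured step tells how this change behaves, so a moderate weakening is expected, beyond the usual scatter. Compound 3 is expected to give 15000 nM, within 4000 nM to 60000 nM, which means a step of a 2.8-fold higher number from compound 2 to compound 3 (0.44 log units; beyond the scatter).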

Compound 3, half-maximal inhibitory concentration: 18900 nM
The estimate for compound 3 lay 1.3-fold (0.10 log units) below the measured number; the range from low to high includes it.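

In this assay the change of hydroxy to methyl on an aromatic carbon now has a measured size, with a 3.5-fold higher number from compound 2 to compound 3 (0.54 log units; beyond the scatter) on the piperidin-1-yl side chain. Piperidin-1-yl in place of 4-methylpiperazin-1-yl on a saturated chain carbon also moves the read-out, with an at least 5.2-fold lower number from compound 1 to compound 3 (0.72 log units; beyond the scatter) as its step. Compound 1 stands at a limit of the assay, so this step gives a bound only: the limit of > 100000 nM in this assay, at which 1 of the 3 values shown sits.

Each change is seen only once, on one background. As far as these compounds go, how a methoxy group or an amine on that aromatic carbon, or a longer chain, would read remains open.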